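Adding a phenyl group to compound 2

The compounds below may be only part of what the source reports. "The series", "measured", "known", "first", "only" and "open" are said of these compounds alone.

Among the measured compounds shown here, in a functional assay on HCT-116 cells (Homo sapiens) for cytotoxicity, read by sulforhodamine B assay, with a stated time of 48 h (on this read-out lower numbers stand for stronger inhibition and higher numbers for weaker inhibition), compound 1 `O=C(Nc1n[nH]c2c1CN(C(=O)c1ccccc1)C2)c1ccccc1` gives 6400 nM, and compound 2 `CC(=O)n1nc(NC(=O)c2ccccc2)c2c1CN(C(=O)c1ccccc1)C2` gives 580 nM, the lower of the two numbers measured so far. Between them lies an 11-fold lower number from compound 1 to compound 2 (1.04 log units; beyond the scatter), a large step beyond the scatter, which comes with acetyl in place of hydrogen on an aromatic nitrogen.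

Compound 3 `CC(=O)n1nc(NC(=O)c2ccccc2)c2c1CN(C(=O)c1ccc(-c3ccccc3)cc1)C2` keeps that acetyl and departs from compound 2 elsewhere: phenyl in place of hydrogen on an aromatic carbon. This is phenyl in place of hydrogen on an aromatic carbon, para to a large group. For the measured compounds named here, no measured step tests a change of this kind. The only one available, an 11-fold lower number from compound 1 to compound 2 (1.04 log units; beyond the scatter), concerns a different place in the molecule, so its size cannot be carried over. The expectation therefore starts from compound 2 at 580 nM. Going by the values given here, no step clearly beyond the scatter is expected in this assay, with a slight lean towards a lower number and wide uncertainty in both directions. The expected change is a 1.7-fold lower number from compound 2 to compound 3 (0.22 log units; within the scatter). For compound 3 the estimated value is 350 nM, with an expected range of 90 nM to 1400 nM.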

Compound 3, half-maximal inhibitory concentration: > 90000 nM
Compound 3 was reported as a limit; the forecaster's own chance of this, stated with the estimate: 5%; middle value at least 250-fold (2.41 log units) away from the limit.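

In this assay, phenyl in place of hydrogen on an aromatic carbon, para to a large group, brings an at least 150-fold higher number from compound 2 to compound 3 (2.19 log units; beyond the scatter), so this position, unchanged across the earlier compounds, is shown to be highly sensitive to this replacement. The acetyl in place of hydrogen on an aromatic nitrogen had come with an 11-fold lower number from compound 1 to compound 2 (1.04 log units; beyond the scatter), yet compound 3 keeps that acetyl and still loses the lower number, so the acetyl alone does not secure it. The value of compound 3, > 90000 nM, is a limit of the assay and not a number, so the true size of the step stays unknown: the limit of > 90000 nM in this assay, at which 1 of the 3 values shown sits.

The compounds shown leave open whether a methyl, a methoxy or a chlorine on the same aromatic carbon would keep the number close to that of compound 2, or whether the loss belongs to phenyl in particular. They also leave open whether an amine or a carboxylic acid on the added phenyl would change the outcome, and whether the same phenyl would act in the same way on compound 1, which lacks the acetyl.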